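A Nitro Group in Place of the Amide Arm

The compounds below may be only part of what the source reports. "The series", "measured", "known", "first", "only" and "open" are said of these compounds alone.

Of the compounds shown here, three sharing one core have been measured in an assay on isolated protein for inhibition of Dihydrofolate reductase (Mus musculus); a lower number here means a less potent compound, a higher number a more potent compound, by a factor of ten per unit of this negative logarithm. Compound 1 `CC1(C)N=C(N)N=C(N)N1c1ccc(Cl)c(OCCCCOc2ccc(S(=O)(=O)F)cc2)c1` gives 7.17. Compound 2 `CN(C)C(=O)c1cccc(NC(=O)NCc2cccc(N3C(N)=NC(N)=NC3(C)C)c2)c1` gives 7.77, and compound 3 `CC1(C)N=C(N)N=C(N)N1c1ccc(OCc2ccc(Cl)c(S(=O)(=O)F)c2)c(Cl)c1` gives 8. Among these three numbers compound 2 stands second highest; the value of compound 3 lies within the usual scatter of it, so the two cannot be told apart, while compound 1 sits lower by a margin beyond that scatter.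

Compound 4 `CC1(C)N=C(N)N=C(N)N1c1cccc(CNC(=O)Nc2cccc([N+](=O)[O-])c2)c1` has not yet been measured in this assay. It differs from compound 2 in one place: nitro in place of dimethylcarbamoyl on an aromatic carbon. Going by the values given here, none of the three measured compounds form a pair that differs in a single place, so no measured step shows what an exchange of this kind does on this core. With nothing in the data pointing either way, the expectation is a step of modest size at most, in either direction, and most likely none beyond the scatter.

The estimate for compound 4 in this assay is 7.6, with a range from 7 to 8.2. That estimate means an expected step of a number 0.17 log units lower from compound 2 to compound 4 (within the scatter).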

Compound 4, logarithm of the reciprocal of the active concentration, log(1/C): 8.1
Beside the measured number, compound 4's estimate is 0.50 log units below it, and the stated range covers the measured number.
By their numbers in this assay, from the lowest: compound 1; then compounds 2, 3 and 4 (each within the scatter of the next, the first and the last beyond it).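

Going by these compounds alone, putting nitro in place of dimethylcarbamoyl on this aromatic carbon gives, in this assay, a number 0.33 log units higher from compound 2 to compound 4 (beyond the scatter) and this is the first single exchange on the shared core whose effect can be read. The step is modest in size, but it shows that at this place, meta to a large group, the dimethylcarbamoyl group is not needed to reach a high number, and that a group with fewer heavy atoms and no carbon does better here. No measurement at hand offers a reason for this step.

As far as these compounds go, it remains open whether the gain belongs to nitro in particular or would also come with other groups on this carbon, such as a nitrile, a carboxylic acid, an amine or plain hydrogen. From the compounds shown here alone, it is also open whether nitro would do the same on another carbon of this ring, or whether this exchange would give a step of like size if other parts of compound 4 were changed.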